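Replacing the methoxyphenoxy arm: a cyclohexylmethyl analogue

A few compounds are considered here, and "the series" means these few. Any claim that something is new, unique, unknown or untested is made for them only; others in the source may bear on it.

Measured compounds:
- compound 1, `COc1ccc(Oc2ccc3c(NCCCNCc4cc(F)ccc4OC)ccnc3c2)cc1`: 14500 nM
- compound 2, `COc1ccc(Oc2ccc3c(NCCCNCc4cccc(OC)c4O)ccnc3c2)cc1`: 14500 nM
- compound 3, `COc1cccc(CNCCCNc2ccnc3cc(Cc4ccc(C#N)cc4)ccc23)c1O`: 4200 nM

In a physicochemical assay for solubility, with a stated time of 18 h, at pH 7.4 (on this read-out lower numbers stand for lower solubility and higher numbers for higher solubility), compound 1 gives 14500 nM, level with compound 2 at the digits given, and together these two stand highest of the three numbers. Compound 3 lies furthest from compound 1, and the step of a 3.5-fold lower number from compound 2 to compound 3 (0.54 log units; beyond the scatter) is the only one beyond the scatter; the step of no change at the digits printed from compound 1 to compound 2 (within the scatter) shows no change.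

Compound 4, `COc1ccc(F)cc1CNCCCNc1ccnc2cc(CC3CCCCC3)ccc12`, has not yet been measured in this assay. It differs from compound 1 by cyclohexylmethyl in place of 4-methoxyphenoxy on an aromatic carbon.

Among the compounds with values here, the step that bears on this change is the one from compound 2 to compound 3, where the same 4-methoxyphenoxy group left the same aromatic carbon and a 4-cyanobenzyl group entered, giving a 3.5-fold lower number from compound 2 to compound 3 (0.54 log units; beyond the scatter). The step from compound 1 to compound 2 is less informative, as it concerns the other end of the molecule. Since a modest lowering accompanied one exchange of the 4-methoxyphenoxy group, a lowering of similar or somewhat larger size is expected here, a 4.8-fold lower number from compound 1 to compound 4 (0.68 log units; beyond the scatter). Compound 4 is therefore estimated at 3000 nM, with a range of 900 nM to 10000 nM.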

Compound 4, solubility: 4200 nM
Estimate against measurement, compound 4: 1.4-fold (0.15 log units) below; low and high end bracket the measured number.
By their numbers in this assay, from the lowest: compounds 3 and 4 (each within the scatter of the next); then compounds 1 and 2 (each within the scatter of the next).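

In this assay, the exchange of 4-methoxyphenoxy for cyclohexylmethyl on this aromatic carbon gives a 3.5-fold lower number from compound 1 to compound 4 (0.54 log units; beyond the scatter). Within the data shown here, until now, the only exchange at this position was the one to 4-cyanobenzyl, a 3.5-fold lower number from compound 2 to compound 3 (0.54 log units; beyond the scatter), so a lowering of this size could have been tied to that group or to the 2-hydroxy-3-methoxyphenyl arm of that pair; it now appears with a non-aromatic ring free of hydrogen-bond acceptors and with the 5-fluoro-2-methoxyphenyl arm at the other end. No measurement here explains the lowering in either pair.

The compounds shown do not separate the loss of the ether oxygen from the loss of the methoxy-bearing aromatic ring, which a cyclohexyloxy group could address. Nor do they show how a morpholinylmethyl group, with its ring nitrogen and oxygen, would read at this position.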